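The source may hold more compounds than are shown below. What is called first, only, known or untested is meant among the compounds shown, and "the series" means these compounds.

Measured in a functional assay on HeLa cells (Homo sapiens) for antiproliferative activity, read by MTT assay, with a stated time of 48 h; a higher number here means a weaker inhibitor, a lower number a stronger inhibitor:
- compound 1 `CCCn1c(N)c(-c2nc3ccccc3[nH]2)c2nc(C#N)c(C#N)nc21`: > 50000 nM, a limit
- compound 2 `N#Cc1nc2c(-c3nc4ccccc4[nH]3)c(N)n(CCCO)c2nc1C#N`: > 50000 nM, a limit

Compound 2 therefore stands only at a limit of the assay, as the limit of > 50000 nM in this assay, at which 2 of the 2 values shown sit, shows. Among the compounds with values here, the single measured step, a step that the two limits leave unreadable from compound 1 to compound 2, offers no size to carry forward. Compound 3 `N#Cc1nc2c(-c3nc4ccccc4[nH]3)c(N)n(CCCN3CCCCC3)c2nc1C#N` has piperidin-1-yl in place of hydroxy on a saturated chain carbon, three bonds along the chain from an aromatic nitrogen. No measured step sizes this change, so only a tentative move toward a lower number is expected in this assay, and another limit remains quite possible. The expected step is an at least 2.5-fold lower number from compound 2 to compound 3 (0.39 log units; beyond the scatter). For compound 3 the estimated value is 20000 nM, with an expected range of 5000 nM to 50000 nM.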

Compound 3, half-maximal inhibitory concentration: 6680 nM
Estimate against measurement, compound 3: 3.0-fold (0.48 log units) above; low and high end bracket the measured number.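

In this assay, within the data shown here, the 3-(piperidin-1-yl)propyl chain gives the only value here that is a number rather than a limit, with an at least 7.4-fold lower number from compound 2 to compound 3 (0.87 log units; beyond the scatter) and an at least 7.4-fold lower number from compound 1 to compound 3 (0.87 log units; beyond the scatter). Neither the 3-hydroxypropyl nor the propyl chain had shown that a change at this place can move the read-out at all. Both steps give only a minimum size, because the other two compounds rest at a limit: the limit of > 50000 nM in this assay, at which 2 of the 3 values shown sit.

As far as these compounds go, it remains open whether the ring or the nitrogen carries the gain: an open-chain amine such as dimethylamino, or morpholin-4-yl, on the same chain would separate the two. A shorter or longer chain would show whether the chain length counts.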